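Methyl on the Outer Phenyl Ring of Hydrazinecarbothioamides

The source may hold more compounds than are shown below. What is called first, only, known or untested is meant among the compounds shown, and "the series" means these compounds.

Three compounds share a hydrazinecarbothioamide core that links a substituted thiophene to an aroyl group, and all were tested in a functional assay on A549 cells (Homo sapiens) for inhibition, read by colorimetric assay and MTT assay, with a stated time of 72 h; on this read-out higher numbers stand for weaker inhibition and lower numbers for stronger inhibition. Compound 1 `O=C(NNC(=S)Nc1csc(-c2ccccc2)c1)c1ccc(O)cc1` gives 75000 nM. Compound 2 `Cc1ccc(-c2cc(NC(=S)NNC(=O)c3ccc(O)cc3)cs2)cc1` carries the change methyl in place of hydrogen on an aromatic carbon and gives 44000 nM; the step of a 1.7-fold lower number from compound 1 to compound 2 (0.23 log units; within the scatter) is recorded as within the scatter, so the two numbers are not told apart here. Compound 3 `COc1cc(OC)cc(C(=O)NNC(=S)Nc2csc(-c3ccccc3)c2)c1` gives 39000 nM; the difference between the core of compound 3 and the core of compound 1 is not broken down here, and its number lies within the scatter of both compound 2 and compound 1.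

Compound 4 `COc1cc(OC)cc(C(=O)NNC(=S)Nc2csc(-c3ccc(C)cc3)c2)c1` is not yet measured. Its change from compound 3, (methyl in place of hydrogen on an aromatic carbon), is the same change as that from compound 1 to compound 2, made at the same place on the same ring. Because a 1.7-fold lower number from compound 1 to compound 2 (0.23 log units; within the scatter) stayed within the scatter, the step from compound 3 to compound 4 is expected to be small as well, and the estimate for the step is a 1.6-fold lower number from compound 3 to compound 4 (0.19 log units; within the scatter). Among the compounds with values here, compound 4 is therefore expected to give about 25000 nM in this assay, with a range from 12000 nM to 50000 nM, resting only on the single earlier instance of this change.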

Compound 4, half-maximal inhibitory concentration: 32000 nM
For compound 4 the middle estimate is 1.3-fold (0.11 log units) below the measured one, within the range that was stated.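

In this assay, the same methyl change, phenyl to 4-methylphenyl, gives a 1.2-fold lower number from compound 3 to compound 4 (0.09 log units; within the scatter). Set beside the earlier instance on the other core, the two steps cannot be told apart, so in this small set the change reads the same on both cores: the same change on two cores in this assay, a 1.7-fold lower number (0.23 log units; within the scatter) from compound 1 to compound 2 and a 1.2-fold lower number (0.09 log units; within the scatter) from compound 3 to compound 4, 1.4-fold (0.15 log units) apart, within the scatter of two such steps

This agreement does not show that methyl in place of hydrogen improves inhibition on either core, since each step on its own lies within the scatter, and the most that can be said is that no step beyond the scatter appears on these two cores. Nor does it show that the change would carry to any further core, as two instances in a single assay are a thin basis for a rule, and two small steps would agree closely whether or not the change had any real effect.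

The compounds shown leave open whether a different group at this same place on the outer ring, such as an amine, a carboxylic acid or a longer chain, would produce a step beyond the scatter on either core. Also open, as far as these compounds go, is whether the methyl change would behave in the same way in any read-out other than this assay.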